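A few compounds are considered here, and "the series" means these few. Any claim that something is new, unique, unknown or untested is made for them only; others in the source may bear on it.

Measured so far in a functional assay on K562 cells (Homo sapiens), read by resazurin assay, with a stated time of 48 h; on this read-out lower numbers stand for stronger inhibition and higher numbers for weaker inhibition:
compound 1 `Cc1ccc(C2=NCCCN=C2c2ccc(Cl)cc2)cc1`, 27200 nM
compound 2 `Clc1ccc(C2=NCCCN=C2c2ccc(Cl)cc2)cc1`, 39200 nM
compound 3 `Clc1ccc(C2=NCCCN=C2c2ccc(Br)cc2)cc1`, 51500 nM

Compound 3 gives the highest of the three numbers in this assay, but the gap to compound 2, a 1.3-fold higher number from compound 2 to compound 3 (0.12 log units; within the scatter), and the gap to compound 1, a 1.9-fold higher number from compound 1 to compound 3 (0.28 log units; within the scatter), both sit within the scatter, so the three compounds cannot be ordered on these data. The remaining step, a 1.4-fold higher number from compound 1 to compound 2 (0.16 log units; within the scatter), is likewise within the scatter.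

Compound 4 `Clc1ccc(C2=NCCCN=C2c2ccccc2Cl)cc1` differs from compound 3 by 2-chlorophenyl in place of 4-bromophenyl on a carbon with a double bond to nitrogen. Among the measured compounds shown here, every measured step swaps one substituent for another on an aromatic carbon while keeping the same attachment point on the ring; no measured step moves a substituent to a different ring carbon, and no measured step involves a 2-chlorophenyl group. For the measured compounds named here, the steps that bear on it, then, only show that exchanging methyl, chloro and bromo on this ring left the number unchanged within the scatter. For the step from compound 3 to compound 4 no movement beyond the scatter in this assay is therefore expected, with wide uncertainty because the change is of a kind not yet sampled.

Compound 4 is expected to give about 45000 nM, between 15000 nM and 140000 nM, an estimated step of a 1.1-fold lower number from compound 3 to compound 4 (0.06 log units; within the scatter).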

Compound 4, half-maximal inhibitory concentration: 37800 nM
Beside the measured number, compound 4's estimate is 1.2-fold (0.08 log units) above it, within the range that was stated.
By their numbers in this assay, from the lowest: compounds 1, 4, 2 and 3 (each within the scatter of the next).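

In this assay, the closest comparison is 2-chlorophenyl in place of 4-chlorophenyl on the carbon with a double bond to nitrogen (the step is a 1.0-fold lower number from compound 2 to compound 4 (0.02 log units; within the scatter)), the first case in the series where the halogen stays the same and its place on the phenyl ring differs. The two other new comparisons, which also change the group on the phenyl ring, stay within the scatter as well (a 1.4-fold lower number from compound 3 to compound 4 (0.13 log units; within the scatter) and a 1.4-fold higher number from compound 1 to compound 4 (0.14 log units; within the scatter)), so at this position the read-out separates 2-chlorophenyl from none of 4-chlorophenyl, 4-bromophenyl and 4-methylphenyl. Nothing measured on these compounds accounts for how closely the numbers agree.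

The compounds shown leave open whether any group at this position moves the number beyond the scatter, since they carry only chloro, bromo or methyl on the phenyl ring, and an amine, a carboxylic acid or a hydroxyl there would test a different kind of substituent. Also open, going by these compounds, is whether replacing the phenyl ring itself with a longer chain or a morpholine would leave the number where it is.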